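The source may report more compounds than this note shows. Statements on the series, on what has been measured and on what is new or still open speak of the compounds shown alone.

The measured compounds in a functional assay on HT cells (Homo sapiens) for antiproliferative activity, read by fluorescence, with a stated time of 72 h (on this read-out higher numbers stand for weaker inhibition of growth and lower numbers for stronger inhibition of growth), are:

compound 1, `CC(C)c1n[nH]c2c(NCc3ccc(-c4ccccn4)cc3)nc(SCCCO)nc12`, which gives 109 nM
compound 2, `CC(C)c1n[nH]c2c(NCc3ccc(-c4ccccn4)cc3)nc(SC3CCCC3O)nc12`, which gives 567 nM
compound 3, `CNCCSc1nc(NCc2ccc(-c3ccccn3)cc2)c2[nH]nc(C(C)C)c2n1`, which gives 56 nM

Compound 3 carries the lowest number of the three, but its separation from compound 1 is only a 1.9-fold lower number from compound 1 to compound 3 (0.29 log units; within the scatter), which lies within the scatter, so the two cannot be ranked; only compound 2 stands apart, at a 10-fold lower number from compound 2 to compound 3 (1.01 log units; beyond the scatter).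

Compound 4, `CCC(O)CSc1nc(NCc2ccc(-c3ccccn3)cc2)c2[nH]nc(C(C)C)c2n1`, has not been measured in this assay. Its change from compound 3 is 1-hydroxypropyl in place of (methylamino)methyl on a saturated chain carbon bound to a sulfur. Among the compounds with values here, two measured steps bear on it. The exchange of hydroxymethyl for methylamino in the same region gave a 1.9-fold lower number from compound 1 to compound 3 (0.29 log units; within the scatter), within the scatter. Moving from the straight 3-hydroxypropyl chain to the 2-hydroxycyclopentyl group gave a 5.2-fold higher number from compound 1 to compound 2 (0.72 log units; beyond the scatter), a modest loss. Compound 4 keeps an open chain with a hydroxyl on the second carbon from the sulfur, so a small loss is expected, a 3.2-fold higher number from compound 3 to compound 4 (0.51 log units; beyond the scatter). Compound 4 is therefore estimated at 180 nM, with a range from 70 nM to 500 nM.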

Compound 4, concentration for 50% growth inhibition: 273 nM
Compound 4: the middle estimate sits 1.5-fold (0.18 log units) below what was measured, and the stated range covers the measured number.
By their numbers in this assay, from the lowest: compounds 3 and 1 (each within the scatter of the next); then compound 4; then compound 2.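

In this assay, 1-hydroxypropyl in place of (methylamino)methyl on a saturated chain carbon bound to a sulfur gave a 4.9-fold higher number from compound 3 to compound 4 (0.69 log units; beyond the scatter), a loss beyond the scatter, whereas the earlier exchange of hydroxymethyl for methylamino had stayed within it. Among the hydroxyl-bearing groups on the sulfur, the order now has three separate levels: 2-hydroxybutyl gave a 2.5-fold higher number from compound 1 to compound 4 (0.40 log units; beyond the scatter) against 3-hydroxypropyl, and a 2.1-fold lower number from compound 2 to compound 4 (0.32 log units; beyond the scatter) against 2-hydroxycyclopentyl, so the open chain recovers part of what the ring lost. No measurement offered here explains these differences.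

Going by these compounds, it remains open how a 2-aminobutyl group or a longer chain ending in a hydroxyl would compare at this position. A carboxylic acid on the same chain is equally unresolved by the compounds shown.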